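Thiazolidinedione replacement at the chain carbon of compound 1

A few compounds are considered here, and "the series" means these few. Any claim that something is new, unique, unknown or untested is made for them only; others in the source may bear on it.

Among the measured compounds shown here, compound 1 `CC(C)C(c1ccc(-c2ccc3cccc(F)c3c2)[nH]c1=O)C1SC(=O)NC1=O` gives 25 nM in an assay on membranes from Chem-1 cells for displacement of a labelled ligand from prostaglandin E2 receptor EP3 subtype (Homo sapiens), read by scintillation counting, with a stated time of 2 h (on this read-out higher numbers stand for weaker inhibition and lower numbers for stronger inhibition), the higher of the two numbers so far. Compound 2 `CC(C)[C@H](C[C@H]1SC(=O)NC1=O)c1ccc(-c2ccc3cccc(F)c3c2)[nH]c1=O`, the nearest comparator, gives 8 nM in this assay, a lower value beyond the scatter. Compound 3 `CC(C)C(/C=C1/C(=O)NC(=O)N1C)c1ccc(-c2ccc3cccc(F)c3c2)[nH]c1=O` carries a group of 9 heavy atoms (5 carbon, 2 nitrogen, 2 oxygen; one five-membered non-aromatic ring with 2 hetero atoms) in place of a group of 7 heavy atoms (3 carbon, 1 nitrogen, 2 oxygen, 1 sulfur; one five-membered non-aromatic ring with 2 hetero atoms), on a saturated chain carbon bound to an aromatic carbon and a saturated chain carbon. For the measured compounds named here, no measured pair isolates this exchange, so the step can only be judged from the size of the change, which is substantial for the group entering with its third double bond outside aromatic rings. A weakening step is expected, a 6.0-fold higher number from compound 1 to compound 3 (0.78 log units; beyond the scatter). Compound 3 is therefore estimated at 150 nM, within 30 nM to 800 nM.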

Compound 3, inhibition constant: 6 nM
The estimate for compound 3 lay 25-fold (1.40 log units) above the measured number; the whole stated range lies above it.
By their numbers in this assay, from the lowest: compounds 3 and 2 (each within the scatter of the next); then compound 1.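

In this assay, replacing the 2,4-dioxo-1,3-thiazolidin-5-yl group on this saturated chain carbon with a larger ring that has no sulfur and carries a third double bond outside aromatic rings improves the read-out (a 4.2-fold lower number from compound 1 to compound 3 (0.62 log units; beyond the scatter)). The sulfur-containing ring is therefore not required at this position. No measurement at hand explains this step.

The exchange alters heavy-atom count, sulfur, double bonds and hydrogen-bond acceptors together, so their separate contributions remain unresolved. Going by these compounds, how a carboxylic acid or an amine would fare at this chain carbon also remains open.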